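A few compounds are considered here, and "the series" means these few. Any claim that something is new, unique, unknown or untested is made for them only; others in the source may bear on it.

In a functional assay on A549 cells (Homo sapiens) for cytotoxicity, read by MTT assay, with a stated time of 72 h (on this read-out lower numbers stand for stronger inhibition and higher numbers for weaker inhibition), compound 2 `O=C(N/N=C/c1ccc(F)cc1Cl)N1CCc2ncnc(Nc3cccc(Br)c3)c2C1` gives 1610 nM and compound 3 `O=C(N/N=C/c1ccc(Br)cc1)N1CCc2ncnc(Nc3cccc(Br)c3)c2C1` gives 6560 nM. Compound 3 thus holds the higher of the two numbers, and the step between them is a 4.1-fold higher number from compound 2 to compound 3 (0.61 log units; beyond the scatter). Compound 4 `O=C(N/N=C/c1cccs1)N1CCc2ncnc(Nc3cccc(Br)c3)c2C1` has thiophen-2-yl in place of 4-bromophenyl on a carbon with a double bond to nitrogen. Among the compounds with values here, no measured step makes this exact exchange. The step from compound 2 is the only one at this place, and it shows that a change here can move the number beyond the scatter. Within the data shown here, compound 1 `O=C(N/N=C/c1cccs1)N1CCc2ncnc(Nc3ccc(F)c(Cl)c3)c2C1`, the only measured compound with thiophen-2-yl, reads > 200000 nM in this assay, which is a limit and not a number. Compound 1 also differs from compound 4 elsewhere in the structure, so it is only a loose guide, yet it points towards weaker inhibition. A step at least as large as the measured one, towards a higher number, is therefore expected. The expected change is a 3.0-fold higher number from compound 3 to compound 4 (0.48 log units; beyond the scatter). For compound 4 the estimated value is 20000 nM, with an expected range from 3000 nM to 130000 nM.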

Compound 4, half-maximal inhibitory concentration: 50300 nM
Compound 4: middle estimate off by 2.5-fold (0.40 log units), on the low side; the range from low to high includes it.
By their numbers in this assay, from the lowest: compound 2; then compound 3; then compound 4. At a limit, above all of these: compound 1.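

With 3-bromophenyl held fixed, the place on a carbon with a double bond to nitrogen now covers three groups, and in this assay thiophen-2-yl gives the highest number of them, with a 7.7-fold higher number from compound 3 to compound 4 (0.88 log units; beyond the scatter) and a 31-fold higher number from compound 2 to compound 4 (1.49 log units; beyond the scatter). Within the data shown here, the same group also opens a first reading of the other place, where 3-bromophenyl in place of 3-chloro-4-fluorophenyl on a nitrogen on an aromatic ring gives an at least 3.9-fold lower number from compound 1 to compound 4 (0.59 log units; beyond the scatter). That step has no fixed size, as the reading of compound 1 is a limit and not a number: the limit of > 200000 nM in this assay, at which 1 of the 4 values shown sits.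

The compounds shown leave open whether a plain phenyl, a furan-2-yl or a pyridin-2-yl at the first place would read nearer compound 2 or nearer compound 4. They also leave open how an amine or a carboxylic acid on that ring would read.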